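Removing the 5-methylthiophen-2-yl group from compound 3

The source may hold more compounds than are shown below. What is called first, only, known or untested is meant among the compounds shown, and "the series" means these compounds.

Of the compounds shown here, three built on a shared core have been measured in a functional assay on A549 cells (Homo sapiens) for antiproliferative activity, read by MTT assay, with a stated time of 48 h; on this read-out higher numbers stand for weaker inhibition of growth and lower numbers for stronger inhibition of growth. In this assay compound 1 (`CCOc1cc(NC(=O)CCCCC(=O)Nc2cc(-c3ccccc3)ccc2N)cc2c1OCC([N+](=O)[O-])=C2`) gives 7460 nM, compound 2 (`CCOc1cc(NC(=O)CCCCCCC(=O)Nc2ccccc2N)cc2c1OCC([N+](=O)[O-])=C2`) gives 11700 nM and compound 3 (`CCOc1cc(NC(=O)CCCCC(=O)Nc2cc(-c3ccc(C)s3)ccc2N)cc2c1OCC([N+](=O)[O-])=C2`) gives 13800 nM. Compound 3 thus stands within the scatter of both compound 1 and compound 2, so these numbers do not separate it from either.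

Compound 4 (`CCOc1cc(NC(=O)CCCCC(=O)Nc2ccccc2N)cc2c1OCC([N+](=O)[O-])=C2`) has not yet been measured. The difference is hydrogen in place of 5-methylthiophen-2-yl on an aromatic carbon, which puts hydrogen in place of 5-methylthiophen-2-yl on an aromatic carbon. For the measured compounds named here, only one measured step touches this place, and it is a 1.8-fold higher number from compound 1 to compound 3 (0.27 log units; within the scatter), with 5-methylthiophen-2-yl in place of phenyl. That step lies within the scatter. Going by the values given here, it exchanges one ring for another, however, and no measured step shows what happens when the ring is lost altogether, so the evidence is indirect and the uncertainty is wide.

No change beyond the scatter is therefore expected in this assay. The expected step is a 1.4-fold lower number from compound 3 to compound 4 (0.14 log units; within the scatter). The estimate for compound 4 is 10000 nM, with an expected range of 4500 nM to 22000 nM.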

Compound 4, concentration for 50% growth inhibition: 9630 nM
Compound 4: the middle estimate sits 1.0-fold (0.02 log units) above what was measured; measured number inside the range.
By their numbers in this assay, from the lowest: compounds 1, 4, 2 and 3 (each within the scatter of the next).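

In this assay, for the compounds shown here, the step of a 1.4-fold lower number from compound 3 to compound 4 (0.16 log units; within the scatter) shows for the first time what happens when the 5-methylthiophen-2-yl ring is lost altogether from this aromatic carbon, and the step of a 1.3-fold higher number from compound 1 to compound 4 (0.11 log units; within the scatter) shows the same loss starting from phenyl. Both steps lie within the scatter, so hydrogen, phenyl and 5-methylthiophen-2-yl are not separated at this place, meta to a large group and para to an amino group, and neither ring is shown to help or harm growth inhibition compared with hydrogen. Nothing available here explains this result.

It remains open whether a carboxylic acid, an amine or a methyl group on this aromatic carbon would also stay within the scatter of hydrogen, since the only substituents shown here are two aromatic rings. On these data alone, it is also open whether a phenyl or a 5-methylthiophen-2-yl group at this place would give the same picture on the longer chain of compound 2.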